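The source may hold more compounds than are shown below. What is called first, only, known or untested is meant among the compounds shown, and "the series" means these compounds.

Values in a functional assay on HCT-116 cells (Homo sapiens) for inhibition, read by sulforhodamine B assay, with a stated time of 2 days; a higher number here means a weaker inhibitor of growth, a lower number a stronger inhibitor of growth:
Compound 1 `CC1=C(C(=O)Nc2ccc(C)cc2)C(c2ccc(O)cc2O)NC(NCc2ccccc2)=N1`: 66700 nM
Compound 2 `CC1=C(C(=O)Nc2cccc([N+](=O)[O-])c2)C(c2ccc(O)cc2O)NC(NCc2ccccc2)=N1`: > 100000 nM
Compound 3 `CC1=C(C(=O)Nc2cccc([N+](=O)[O-])c2)C(c2ccc(O)cc2O)NC(Nc2ccc(S(=O)(=O)Nc3cc(C)on3)cc2)=N1`: 16600 nM

Compound 2 gives > 100000 nM, which is a limit and not a number. It stands at the limit of > 100000 nM in this assay, at which 1 of the 3 values shown sits. The next change, to compound 4 `CC1=C(C(=O)Nc2cccc([N+](=O)[O-])c2)C(c2ccc(O)cc2O)NC(N/N=C/c2ccco2)=N1`, is a group of 7 heavy atoms (5 carbon, 1 nitrogen, 1 oxygen; one five-membered aromatic ring with 1 hetero atom) in place of a group of 7 heavy atoms (7 carbon; one six-membered aromatic ring of carbon only), on an amine nitrogen: benzyl leaves, and a group with a five-membered aromatic ring with 1 hetero atom enters, on an amine nitrogen. Going by the values given here, the only measured step, an at least 1.4-fold higher number from compound 1 to compound 2 (0.17 log units; that floor lies within the scatter), lies on an amide-type nitrogen, so it bears only weakly on this change. Among the compounds with values here, compound 1 at 66700 nM and compound 3 at 16600 nM give the only numbers, so a modest move to a lower number is expected in this assay. The expected step is an at least 1.6-fold lower number from compound 2 to compound 4 (0.22 log units; that floor lies within the scatter). For compound 4 the estimate is 60000 nM, with an expected range of 20000 nM to 100000 nM.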

Compound 4, concentration for 50% growth inhibition: 8890 nM
The estimate for compound 4 lay 6.7-fold (0.83 log units) above the measured number; the whole stated range lies above it.
By their numbers in this assay, from the lowest: compounds 4 and 3 (each within the scatter of the next); then compound 1. At a limit, above all of these: compound 2.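

Compound 2 stands at a limit and not at a number: the limit of > 100000 nM in this assay, at which 1 of the 4 values shown sits. In this assay, benzyl giving way on the amine nitrogen to the group with a five-membered aromatic ring with 1 hetero atom gives an at least 11-fold lower number from compound 2 to compound 4 (1.05 log units; beyond the scatter), so this position can carry a large step with the 3-nitrophenyl amide held fixed. Compound 3 at 16600 nM and compound 4 at 8890 nM lie within the scatter of each other, though their groups on this nitrogen differ.

Open, from the compounds shown here alone, is whether the step follows the aromatic ring or the double bond outside it. Also open, going by these compounds, is how a simple alkyl chain or a carboxylic acid on this nitrogen would read.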